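A few compounds are considered here, and "the series" means these few. Any claim that something is new, unique, unknown or untested is made for them only; others in the source may bear on it.

Measured in a functional assay on HEK293 cells for antagonist activity at proteinase-activated receptor 4 (Homo sapiens), read by FLIPR and calcium flux, with a stated time of 30 min; a lower number here means a stronger inhibitor, a higher number a weaker inhibitor:
- compound 1 `COc1cc(OCc2csc(-c3ccc(C(F)(F)F)cc3)n2)c2cc(-c3cn4nc(OC)sc4n3)oc2c1`: 1.3 nM
- compound 2 `COc1cc(OCc2csc(-c3cccc(C(=O)N(C)C)c3)n2)c2cc(-c3cn4nc(OC)sc4n3)oc2c1`: 0.8 nM

Compound 2 gives the lowest of the two numbers in this assay, but its gap from compound 1 is within the scatter: a 1.6-fold lower number from compound 1 to compound 2 (0.21 log units; within the scatter). Compound 3 `COc1cc(OCc2csc(-c3ccc(C(C)(C)O)cc3)n2)c2cc(-c3cn4nc(OC)sc4n3)oc2c1` carries 4-(1-hydroxy-1-methylethyl)phenyl in place of 3-(dimethylcarbamoyl)phenyl on an aromatic carbon. Among the measured compounds shown here, the only measured step at this aromatic carbon, a 1.6-fold lower number from compound 1 to compound 2 (0.21 log units; within the scatter), lay within the scatter, so exchanging one substituted phenyl for another here has not yet moved the number. The expectation for compound 3 is therefore a step of a 1.5-fold higher number from compound 2 to compound 3 (0.18 log units; within the scatter), within the scatter. Compound 3 is estimated at 1.2 nM, with a range from 0.5 nM to 3 nM.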

Compound 3, half-maximal inhibitory concentration: 2.4 nM
The estimate for compound 3 lay 2.0-fold (0.30 log units) below the measured number; low and high end bracket the measured number.
By their numbers in this assay, from the lowest: compounds 2, 1 and 3 (each within the scatter of the next, the first and the last beyond it).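

In this assay this aromatic carbon of the five-membered ring now shows a modest step beyond the scatter, a 3.0-fold higher number from compound 2 to compound 3 (0.48 log units; beyond the scatter), with 4-(1-hydroxy-1-methylethyl)phenyl in place of 3-(dimethylcarbamoyl)phenyl. With 1-hydroxy-1-methylethyl in place of trifluoromethyl, the step stays within the scatter, a 1.8-fold higher number from compound 1 to compound 3 (0.27 log units; within the scatter), so only compound 2 and compound 3 separate. Nothing available explains this gap.

The step from compound 2 to compound 3 changes both the group and its place on the phenyl, and these compounds cannot separate the two. From the compounds shown here alone, whether an amine or a carboxylic acid on that phenyl would keep the number this low remains open.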